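The compounds below may be only part of what the source reports. "The series", "measured", "known", "first", "only" and "open" are said of these compounds alone.

Measured compounds:
- Compound 1, `COc1ccc(C2=Nn3c(nnc3C(C)c3ccc4cc(OC)ccc4c3)SC2)cc1`, gives 6500 nM in a functional assay on HCT-116 cells (Homo sapiens) for inhibition, read by sulforhodamine B assay, with a stated time of 72 h; a lower number here means a stronger inhibitor, a higher number a weaker inhibitor.
- Compound 2, `COc1ccc2cc(C(C)c3nnc4n3N=C(c3ccc(Cl)cc3)CS4)ccc2c1`, gives 8800 nM in this assay.

Compound 2 has the higher of the two numbers seen so far; its nearest neighbour is compound 1, and the gap between them, a 1.4-fold higher number from compound 1 to compound 2 (0.13 log units; within the scatter), lies within the scatter of repeated measurements, so the two cannot be told apart on these numbers. The unmeasured compound 3, `COc1ccc2cc(C(C)c3nnc4n3N=C(c3ccc(C(F)(F)F)cc3)CS4)ccc2c1`, differs from compound 2 in one place: trifluoromethyl in place of chloro on an aromatic carbon. Within the data shown here, only one measured step bears on this position: a 1.4-fold higher number from compound 1 to compound 2 (0.13 log units; within the scatter), which swapped one small group for another at the same place and produced no change beyond the scatter. A second swap at the same place gives no reason, on this evidence alone, to expect a large move in either direction. The number for compound 3 in this assay is therefore expected to stay close to that of compound 2, with the step of a 1.0-fold higher number from compound 2 to compound 3 (0.01 log units; within the scatter) reflecting that expectation. For compound 3 the estimate is 9000 nM, with a range from 3000 nM to 27000 nM.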

Compound 3, half-maximal inhibitory concentration: 10800 nM
Compound 3: the middle estimate sits 1.2-fold (0.08 log units) below what was measured, within the range that was stated.
By their numbers in this assay, from the lowest: compounds 1, 2 and 3 (each within the scatter of the next).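

In this assay, the swap at this position brings in trifluoromethyl, with 4 heavy atoms, where chloro has 1 heavy atom, and the result is a 1.2-fold higher number from compound 2 to compound 3 (0.09 log units; within the scatter). So even this difference in atom count, on an aromatic carbon para to a large group, does not separate the two compounds. The wider comparison of trifluoromethyl with methoxy gives a 1.7-fold higher number from compound 1 to compound 3 (0.22 log units; within the scatter), which means that the three groups now seen at this place, methoxy, chloro and trifluoromethyl, cannot be told apart on these numbers, and nothing available here offers an explanation for that.

Going by these compounds, the three groups seen here carry no net charge and no hydrogen-bond donor, so it remains open whether an amine, a carboxylic acid or a longer chain at this position would shift the number beyond the scatter. On these data alone, it is also open whether a change elsewhere on the shared core, such as on the methoxy-bearing side of the molecule that all three compounds have in common, would have a larger effect than these swaps.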